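The source may report more compounds than this note shows. Statements on the series, on what has been measured and on what is new or still open speak of the compounds shown alone.

Compound 1 `COc1ccccc1-c1ncnn1-c1cc(OC)c(OC)c(OC)c1` and compound 2 `COc1cc(-c2ncnn2-c2ccccc2)cc(OC)c1OC` share the same core, each carrying two aromatic rings on it. In a functional assay on A549 cells (Homo sapiens) for antiproliferative activity, read by MTT assay, with a stated time of 72 h (on this read-out higher numbers stand for weaker inhibition and lower numbers for stronger inhibition), compound 1 gives only a limit of the assay, > 10000 nM. In this assay compound 2 likewise gives only a limit, > 10000 nM. Among the compounds with values here, both known values therefore sit at the same limit (the limit of > 10000 nM in this assay, at which 2 of the 2 values shown sit), so compound 2 stands at the edge of what the assay can report, and no measured step exists between compounds that differ in a single place. Compound 3 `COc1cc(-c2ncnn2-c2ccc(Cl)cc2Cl)cc(OC)c1OC` differs from compound 2 by one change (2,4-dichlorophenyl in place of phenyl on an aromatic nitrogen). With both known values being limits, the data give no direction for this change, and the step expected here, an at least 1.2-fold lower number from compound 2 to compound 3 (0.09 log units; that floor lies within the scatter), is none beyond the usual scatter. Compound 3 is estimated at 8000 nM, within a range from 1000 nM to 30000 nM, with a real chance that the assay again reports only a limit.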

Compound 3, half-maximal inhibitory concentration: > 10000 nM
Compound 3 gave a limit, no number; the forecaster's own chance of this, stated with the estimate: 55%; middle value at least 1.2-fold (0.09 log units) away from the limit.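

In this assay compound 3 gives only a limit, > 10000 nM. No step can be read between compound 2 and compound 3, because both sit at the same limit: the limit of > 10000 nM in this assay, at which 3 of the 3 values shown sit.

The compounds shown leave open whether 2,4-dichlorophenyl in place of phenyl changes the activity at all.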